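The source may hold more compounds than are shown below. What is called first, only, known or untested is meant among the compounds shown, and "the series" means these compounds.

Measured so far in a functional assay on MCF7 cells (Homo sapiens) for inhibition, read by sulforhodamine B assay, with a stated time of 48 h; on this read-out lower numbers stand for stronger inhibition and higher numbers for weaker inhibition:
compound 1 `CSc1nn(-c2ccccc2)c2ncnc(N/N=C/c3ccc(Cl)cc3)c12` gives 12.1 nM;
compound 2 `CSc1nn(-c2ccccc2)c2ncnc(N/N=C/c3ccc(F)cc3)c12` gives 7.5 nM;
compound 3 `CSc1nn(-c2ccccc2)c2ncnc(N/N=C/c3ccc([N+](=O)[O-])cc3Cl)c12` gives 15.7 nM.

Compound 2 holds the lowest number of the three; the steps that involve it are a 1.6-fold lower number from compound 1 to compound 2 (0.21 log units; within the scatter) and a 2.1-fold higher number from compound 2 to compound 3 (0.32 log units; beyond the scatter). Compound 4 `COc1ccc(-n2nc(SC)c3c(N/N=C/c4ccc(F)cc4)ncnc32)cc1` is not yet measured. It differs from compound 2 by methoxy in place of hydrogen on an aromatic carbon, on the phenyl attached to the shared core. For the measured compounds named here, every measured step in this assay (a 1.6-fold lower number from compound 1 to compound 2 (0.21 log units; within the scatter), a 1.3-fold higher number from compound 1 to compound 3 (0.11 log units; within the scatter), a 2.1-fold higher number from compound 2 to compound 3 (0.32 log units; beyond the scatter)) alters the aryl on the hydrazone carbon, and none touches the phenyl on the core, so no measured step bears on this change. With all three measured numbers lying close together, no step beyond the scatter is expected. Compound 4 is therefore estimated at 8 nM, with a range of 3 nM to 22 nM, amounting to an expected step of a 1.1-fold higher number from compound 2 to compound 4 (0.03 log units; within the scatter) from compound 2.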

Compound 4, half-maximal inhibitory concentration: 12.1 nM
For compound 4 the middle estimate is 1.5-fold (0.18 log units) below the measured one; measured number inside the range.
By their numbers in this assay, from the lowest: compounds 2, 1, 4 and 3 (each within the scatter of the next, the first and the last beyond it).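

For the compounds shown here, the phenyl to 4-methoxyphenyl change gives the first reading on the phenyl of the shared core, and in this assay it amounts to a 1.6-fold higher number from compound 2 to compound 4 (0.21 log units; within the scatter). At this place, para to a large group, methoxy is therefore accommodated without a step beyond the scatter, while the aryl on the hydrazone carbon stays 4-fluorophenyl. No available evidence bears on the reason for this result.

Open, going by these compounds, is whether an amine or a carboxylic acid on this phenyl would stay equally close, and whether methoxy would read the same alongside 4-chlorophenyl on the hydrazone carbon.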